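Swapping the Side Chain of Compound 2

A few compounds are considered here, and "the series" means these few. Any claim that something is new, unique, unknown or untested is made for them only; others in the source may bear on it.

In a functional assay on V79 cells (Cricetulus griseus) for cytotoxicity, read by colony formation (on this read-out lower numbers stand for stronger inhibition and higher numbers for weaker inhibition), compound 1 `CC1(CN)CCN(c2c(F)cc3c(=O)c(C(=O)O)cn(C4CC4)c3c2Cl)C1` gives 8 ug/mL, compound 2 `COc1c(N2CCC(C)(CN)C2)c(F)cc2c(=O)c(C(=O)O)cn(C3CC3)c12` gives 38 ug/mL and compound 3 `CC1(CN)CCN(c2c(F)cc3c(=O)c(C(=O)O)cn(C4CC4)c3c2C(F)(F)F)C1` gives 110 ug/mL. Compound 2 therefore holds the second highest of the three numbers. Among the compounds with values here, compound 4 `COc1c(N2CCNCC2)c(F)cc2c(=O)c(C(=O)O)cn(C3CC3)c12` keeps the methoxy group of compound 2, and its one change is piperazin-1-yl in place of 3-(aminomethyl)-3-methylpyrrolidin-1-yl on an aromatic carbon.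

Within the data shown here, no measured step makes this exact swap. All three compounds carry the same 3-(aminomethyl)-3-methylpyrrolidin-1-yl group and differ in another group on the aromatic ring. Those changes still show how far one swap can move the number in this assay: a 4.8-fold higher number from compound 1 to compound 2 (0.68 log units; beyond the scatter) for methoxy in place of chloro, and a 2.9-fold higher number from compound 2 to compound 3 (0.46 log units; beyond the scatter) for trifluoromethyl in place of methoxy. Both steps are modest, so a step of similar size is a reasonable guess, though the direction is only a tentative lean towards a higher number. The expected change is a 2.4-fold higher number from compound 2 to compound 4 (0.37 log units; beyond the scatter). Compound 4 is estimated at 90 ug/mL, with an expected range from 25 ug/mL to 300 ug/mL.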

Compound 4, half-maximal inhibitory concentration: 82 ug/mL
Estimate against measurement, compound 4: 1.1-fold (0.04 log units) above, and the stated range covers the measured number.
By their numbers in this assay, from the lowest: compound 1; then compound 2; then compounds 4 and 3 (each within the scatter of the next).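

The earlier compounds shown here all carry 3-(aminomethyl)-3-methylpyrrolidin-1-yl and differ only in another group on the aromatic ring, so they say nothing about changing that side chain. With the methoxy group held fixed, the aromatic carbon ortho to the fluoro and methoxy groups also proves sensitive in this assay: piperazin-1-yl in place of 3-(aminomethyl)-3-methylpyrrolidin-1-yl gives a 2.2-fold higher number from compound 2 to compound 4 (0.33 log units; beyond the scatter), a modest step but one beyond the scatter. No measured evidence is available to explain this step.

From the compounds shown here alone, whether piperazin-1-yl would move the number by a similar amount with chloro or trifluoromethyl in place of methoxy remains open. So does the effect of morpholin-4-yl, a six-membered ring with oxygen in place of one piperazine nitrogen, on this same aromatic carbon.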